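The compounds below may be only part of what the source reports. "The series", "measured", "known", "first", "only" and "open" are said of these compounds alone.

In an assay on CHO cells for antagonist activity at transient receptor potential cation channel subfamily V member 1 (Homo sapiens), read by FLIPR (a lower number here means a stronger inhibitor, a higher number a weaker inhibitor), the three measured compounds stand as follows:

compound 1, `CC(C(=O)NCc1ccc(C(F)(F)F)cc1N1CCC(C(F)(F)F)CC1)c1ccc(NS(C)(=O)=O)c(F)c1`, gives 0.4 nM
compound 2, `CCCCSc1cc(C(F)(F)F)ccc1CNC(=O)C(C)c1ccc(NS(C)(=O)=O)c(F)c1`, gives 1.9 nM
compound 3, `COc1ccc(CSc2cc(C(F)(F)F)ccc2CNC(=O)C(C)c2ccc(NS(C)(=O)=O)c(F)c2)cc1`, gives 2.3 nM

Compound 1 has the lowest number of the three in this assay. Its nearest neighbour is compound 2, with a 4.8-fold higher number from compound 1 to compound 2 (0.68 log units; beyond the scatter), and the furthest is compound 3, with a 5.8-fold higher number from compound 1 to compound 3 (0.76 log units; beyond the scatter). The two neighbours sit close to each other: a 1.2-fold higher number from compound 2 to compound 3 (0.08 log units; within the scatter).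

Compound 4, `CCCCCc1cc(C(F)(F)F)ccc1CNC(=O)C(C)c1ccc(NS(C)(=O)=O)c(F)c1`, is the next compound to follow from compound 1. The change is pentyl in place of 4-(trifluoromethyl)piperidin-1-yl on an aromatic carbon.

Both measured steps away from compound 1 change the same group on the same aromatic carbon, putting butylsulfanyl or (4-methoxybenzyl)sulfanyl in place of 4-(trifluoromethyl)piperidin-1-yl, and each gave a modest weakening. Pentyl is another replacement at that carbon, so compound 4 is expected to show a weakening of similar modest size in this assay, that is a 5.0-fold higher number from compound 1 to compound 4 (0.70 log units; beyond the scatter). The estimate for compound 4 is therefore 2 nM, with an expected range from 0.7 nM to 6 nM.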

Compound 4, inhibition constant: 0.4 nM
Compound 4: the middle estimate sits 5.0-fold (0.70 log units) above what was measured; measured number outside the range, below it.
By their numbers in this assay, from the lowest: compounds 1 and 4 (each within the scatter of the next); then compounds 2 and 3 (each within the scatter of the next).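

Pentyl can stand in for 4-(trifluoromethyl)piperidin-1-yl on this aromatic carbon in this assay with no readable loss (no change at the digits printed from compound 1 to compound 4 (within the scatter)), even though it brings no ring and no hydrogen-bond acceptor. The weakening seen earlier therefore does not follow from every replacement at this position: it appears with the two sulfanyl groups, as the steps to pentyl show (a 4.8-fold lower number from compound 2 to compound 4 (0.68 log units; beyond the scatter); a 5.8-fold lower number from compound 3 to compound 4 (0.76 log units; beyond the scatter)). The data shown offer no measurement that accounts for these differences.

On these data alone, how far this tolerance extends remains open, since a shorter chain such as propyl, a longer chain such as heptyl and a butoxy group could each behave differently at this carbon. It is also unknown whether a pentyl chain ending in an amine or a carboxylic acid would keep the number of compound 4.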